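Methylsulfanyl for methyl on the pyrazoline aryl ring

The source may report more compounds than this note shows. Statements on the series, on what has been measured and on what is new or still open speak of the compounds shown alone.

Measured compounds:
compound 1 `S=C(Nc1ccccc1)N1N=C(c2ccccc2)CC1c1ccc2c(c1)OCCO2`, 6630 nM
compound 2 `Fc1ccc(C2=NN(C(=S)Nc3ccccc3)C(c3ccc4c(c3)OCCO4)C2)cc1`, 37600 nM
compound 3 `Cc1ccc(C2=NN(C(=S)Nc3ccccc3)C(c3ccc4c(c3)OCCO4)C2)cc1`, 19500 nM

In a functional assay on HT-29 cells (Homo sapiens) for antiproliferative activity, read by MTT assay, with a stated time of 48 h (on this read-out higher numbers stand for weaker inhibition of growth and lower numbers for stronger inhibition of growth), compound 3 gives 19500 nM, the second highest of the three numbers. Its nearest neighbour is compound 2, and the step of a 1.9-fold lower number from compound 2 to compound 3 (0.29 log units; within the scatter) lies within the scatter, so no order between these two is claimed. Compound 1 stands apart: the step of a 2.9-fold higher number from compound 1 to compound 3 (0.47 log units; beyond the scatter) is beyond the scatter, and so is a 5.7-fold higher number from compound 1 to compound 2 (0.75 log units; beyond the scatter).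

Compound 4 `CSc1ccc(C2=NN(C(=S)Nc3ccccc3)C(c3ccc4c(c3)OCCO4)C2)cc1` differs from compound 3 in one place: methylsulfanyl in place of methyl on an aromatic carbon. For the measured compounds named here, no measured step pairs methyl with methylsulfanyl, so the bearing steps are indirect. Both substitutions at this aromatic carbon that have been measured, a 5.7-fold higher number from compound 1 to compound 2 (0.75 log units; beyond the scatter) and a 2.9-fold higher number from compound 1 to compound 3 (0.47 log units; beyond the scatter), gave higher numbers, of modest size, and the exchange of one such group for another, a 1.9-fold lower number from compound 2 to compound 3 (0.29 log units; within the scatter), stayed within the scatter. A further exchange of one group for another at the same carbon is therefore expected to move the number little, if at all beyond the scatter, with a slight lean toward a higher number.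

Compound 4 is expected to give 25000 nM, with a range from 8000 nM to 80000 nM. The expected step is a 1.3-fold higher number from compound 3 to compound 4 (0.11 log units; within the scatter).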

Compound 4, concentration for 50% growth inhibition: > 200000 nM
Compound 4: only a limit was reported (the forecaster's own chance of this, stated with the estimate: 10%); at least 8.0-fold (0.90 log units) between middle value and limit.
By their numbers in this assay, from the lowest: compound 1; then compounds 3 and 2 (each within the scatter of the next). At a limit, above all of these: compound 4.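

At this position, on an aromatic carbon para to a large group, fluoro and methyl had moved the number only modestly from hydrogen and had stayed within the scatter of each other, so the position looked forgiving. Methylsulfanyl breaks that picture in this assay: it gives an at least 10-fold higher number from compound 3 to compound 4 (1.01 log units; beyond the scatter), along with an at least 5.3-fold higher number from compound 2 to compound 4 (0.72 log units; beyond the scatter) and an at least 30-fold higher number from compound 1 to compound 4 (1.47 log units; beyond the scatter), so the change from 4-methylphenyl to 4-(methylsulfanyl)phenyl, which adds one sulfur to the group, matters far more than the earlier exchanges did. Compound 4 is reported only as a limit, so each of these three steps gives a minimum size and not a measured one: the limit of > 200000 nM in this assay, at which 1 of the 4 values shown sits.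

The compounds shown cannot tell whether the sulfur itself or the extra heavy atom goes with the loss of growth inhibition, and a methoxy or an ethyl group on the same carbon would separate the two. Going by these compounds, how far the true value of compound 4 lies past its limit also stays open, as does whether a sulfur-linked group such as methylsulfonyl would behave in the same way.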